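The compounds below may be only part of what the source reports. "The series", "measured", "known", "first", "only" and "open" are said of these compounds alone.

Measured compounds in a functional assay on A549 cells (Homo sapiens) for cytotoxicity, read by MTT assay, with a stated time of 72 h; a lower number here means a stronger inhibitor, a higher number a weaker inhibitor:
- compound 1 `Cc1cc(=O)n(-c2cccc(F)c2)nc1C(=O)Nc1ccc(Oc2ncnc3[nH]ccc23)cc1`: 34800 nM
- compound 2 `Cc1cc(=O)n(-c2cccc(F)c2)nc1C(=O)Nc1ccc(Oc2ncnc3[nH]ccc23)c(F)c1`: 31500 nM
- compound 3 `Cc1cc(=O)n(-c2cccc(F)c2)nc1C(=O)Nc1ccc(Oc2ncnc3c2ccn3C)cc1`: 23400 nM

The three numbers sit close together. The step of a 1.1-fold lower number from compound 1 to compound 2 (0.04 log units; within the scatter) and the step of a 1.5-fold lower number from compound 1 to compound 3 (0.17 log units; within the scatter) both fall within the scatter, and the gap between compound 3 and compound 2 is likewise within the scatter, so on the present numbers compound 3 cannot be told apart from compound 1 or compound 2; it is one of three near-equal values.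

Compound 4 `Cc1cc(=O)n(-c2ccccc2Cl)nc1C(=O)Nc1ccc(Oc2ncnc3c2ccn3C)cc1` differs from compound 3 by 2-chlorophenyl in place of 3-fluorophenyl on an aromatic nitrogen, the group sitting on an aromatic nitrogen of a six-membered aromatic ring with 2 nitrogen, next to the ring nitrogen. Neither measured step bears on this position: the step from compound 1 to compound 2 concerns a fluoro on the anilide ring, the step from compound 1 to compound 3 a methyl on the other ring nitrogen of the core. For the measured compounds named here, there is thus no measured step on the aryl attached to this nitrogen, and no basis for expecting a shift in a particular direction. Compound 4 is expected to show a step of a 1.0-fold lower number from compound 3 to compound 4 (0.01 log units; within the scatter) that stays within the scatter. For compound 4 the estimate in this assay is 23000 nM, with a range from 7000 nM to 75000 nM.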

Compound 4, half-maximal inhibitory concentration: 5120 nM
Compound 4: the middle estimate sits 4.5-fold (0.65 log units) above what was measured; measured number outside the range, below it.
By their numbers in this assay, from the lowest: compound 4; then compounds 3, 2 and 1 (each within the scatter of the next).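

In this assay, for the compounds shown here, the aryl on this aromatic nitrogen is the first place where a single change moves the number beyond the scatter: a 4.6-fold lower number from compound 3 to compound 4 (0.66 log units; beyond the scatter), a modest step, with 2-chlorophenyl in place of 3-fluorophenyl, whereas the two earlier steps on other parts of the molecule both stayed within the scatter. The aryl on this nitrogen is therefore a position where the cytotoxicity read-out responds to substitution, though this rests on a single pair of compounds. The change alters both the halogen and its place on the phenyl ring, the compounds shown do not separate these two effects, and nothing available explains the step.

On these data alone, it remains open whether 2-fluorophenyl or 3-chlorophenyl would follow compound 4 or compound 3, and how an unsubstituted phenyl, a 2-methoxyphenyl or a 2-aminophenyl on this nitrogen would compare. Also open, as far as these compounds go, is whether 2-chlorophenyl would give a similar step on the core of compound 1, which keeps the hydrogen on the other ring nitrogen in place of the methyl.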